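Triazole series: pyridyl isomer swap at the five-membered ring

This account rests on a few compounds, and the source may have more. Where it says the series, first, only, none or still open, it means among the compounds named here.

Measured so far:
compound 1 `Nc1nc(-c2ccc(Cl)cc2)nn1-c1ncnc2cc(Cl)ccc12` — > 40000 nM
compound 2 `COc1cc2ncnc(-n3nc(-c4cccnc4)nc3N)c2cc1OC` — 15000 nM

In an assay on MCF7 cells for inhibition of Serine-protein kinase ATM (Homo sapiens), read by immunofluorescence, with a stated time of 1 h (a lower number here means a stronger inhibitor, a higher number a weaker inhibitor), compound 1 returns only a limit, > 40000 nM, and no number. Among the measured compounds shown here, compound 2 is the only compound with a number in this assay, 15000 nM. One further value sits at the limit (the limit of > 40000 nM in this assay, at which 1 of the 2 values shown sits). Compound 3 `COc1cc2ncnc(-n3nc(-c4ccncc4)nc3N)c2cc1OC` differs from compound 2 by pyridin-4-yl in place of pyridin-3-yl on an aromatic carbon between two ring nitrogen atoms. For the measured compounds named here, no measured step of this kind is available, so no direction beyond the scatter is expected. Compound 3 is estimated at 12000 nM, range 3000 nM to 40000 nM, an expected step of a 1.3-fold lower number from compound 2 to compound 3 (0.10 log units; within the scatter).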

Compound 3, half-maximal inhibitory concentration: 5000 nM
Compound 3: the middle estimate sits 2.4-fold (0.38 log units) above what was measured; the range from low to high includes it.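

In this assay, the aromatic carbon between two ring nitrogen atoms proves sensitive to a change that leaves the atoms of the group unchanged: pyridin-4-yl in place of pyridin-3-yl gives a 3.0-fold lower number from compound 2 to compound 3 (0.48 log units; beyond the scatter). Among the compounds shown here, this is the first step read, and it is modest; compound 3 still sits at 5000 nM. Nothing at hand explains the step.

Open, from the compounds shown here alone, is how pyridin-2-yl, or a phenyl ring carrying an amine or a carboxylic acid, would read at this position. Also open, going by these compounds, is whether the step carries over to the core of compound 1.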